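Chalcone boronic esters: aryl ketone replacing pyrrolyl ketone

A few compounds are considered here, and "the series" means these few. Any claim that something is new, unique, unknown or untested is made for them only; others in the source may bear on it.

Working notes on the series. The shared core carries an enone with an aryl group on the carbonyl carbon. Compound 1 `Cn1cccc1C(=O)/C=C/c1ccc2c(c1)B(O)OC2` is the 1-methyl-1H-pyrrol-2-yl ketone. In a functional assay on HCT-116 cells (Homo sapiens) for cytotoxicity, read by MTT assay, with a stated time of 48 h (on this read-out higher numbers stand for weaker inhibition and lower numbers for stronger inhibition), compound 1 gives only a limit, > 100000 nM, so it is the weakest value shown but no number is known for it (the limit of > 100000 nM in this assay, at which 1 of the 2 values shown sits). Compound 2 `O=C(/C=C/c1ccc2c(c1)B(O)OC2)c1ccc(OCc2ccccc2)cc1` is the benzyloxyphenyl ketone; in this assay compound 2 gives 12100 nM.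

Compound 3 `O=C(/C=C/c1ccc2c(c1)B(O)OC2)c1ccccc1F` has not been measured. Relative to compound 1 the change is 2-fluorophenyl in place of 1-methyl-1H-pyrrol-2-yl on a carbonyl carbon. For the measured compounds named here, no measured step connects these two, and compound 2 is the only other point of comparison. Since compound 2 with an aryl ketone sits at 12100 nM, compound 3 is expected to show a gain; the step of an at least 4.0-fold lower number from compound 1 to compound 3 (0.60 log units; beyond the scatter) is estimated to go beyond the scatter, toward stronger inhibition. The estimate for compound 3 in this assay is 25000 nM, with a range from 8000 nM to 100000 nM.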

Compound 3, half-maximal inhibitory concentration: 4200 nM
The estimate for compound 3 lay 6.0-fold (0.77 log units) above the measured number, outside the stated range (below it).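

On this carbonyl carbon, 2-fluorophenyl in place of 1-methyl-1H-pyrrol-2-yl gives, in this assay, an at least 23-fold lower number from compound 1 to compound 3 (1.37 log units; beyond the scatter), so the benzyloxyphenyl ketone is not the only aryl ketone with a measurable value. Compound 2 gives 12100 nM and compound 3 gives 4200 nM, the lower printed number of the two belonging to the 2-fluorophenyl ketone. The size of the step from the pyrrolyl ketone is only a lower bound, since compound 1 stands at a limit and not at a number: the limit of > 100000 nM in this assay, at which 1 of the 3 values shown sits.

The compounds shown leave open how much of the gain belongs to the fluorine and how much to the six-membered aromatic ring, a question that an unsubstituted phenyl or a chlorophenyl ketone would address. As far as these compounds go, whether a pyridyl ketone or an aminophenyl ketone would keep this level also remains open.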